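This account rests on a few compounds, and the source may have more. Where it says the series, first, only, none or still open, it means among the compounds named here.

Measured in a functional assay on MDA-MB-435 cells (Homo sapiens) for inhibition, read by sulforhodamine B assay, with a stated time of 48 h; a higher number here means a weaker inhibitor of growth, a lower number a stronger inhibitor of growth:
- compound 1 `O=C(CCCCN1C/C=C/CCOc2cccc(c2)-c2ccnc(n2)Nc2cccc(c2)C1)NO`: 2720 nM
- compound 2 `O=C(CCCCCCN1C/C=C/COCc2cccc(c2)-c2ccnc(n2)Nc2cccc(c2)C1)NO`: 1500 nM

Only these two compounds have been measured so far, and they differ in more than one place. Going by the values given here, compound 1, at 2720 nM, and compound 2, at 1500 nM, lie within the scatter of each other, so this assay does not separate them, and compound 1 stands level with the only other number available.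

Compound 3 `O=C(CCCCC(=O)N1C/C=C/CCOc2cccc(c2)-c2ccnc(n2)Nc2cccc(c2)C1)NO`, not yet measured, keeps the core of compound 1 and changes one substituent. On an amine nitrogen in a ring, (4-(hydroxycarbamoyl)butyl)carbonyl stands in place of 4-(hydroxycarbamoyl)butyl ((4-(hydroxycarbamoyl)butyl)carbonyl in place of 4-(hydroxycarbamoyl)butyl on an amine nitrogen in a ring). The added carbonyl is the only difference between the two structures. Among the compounds with values here, no measured pair shows this kind of change, so the data give no direct guide to its size or direction. The starting point is therefore compound 1 at 2720 nM, and the range must stay wide.

The expected step is none beyond the scatter, a 1.1-fold higher number from compound 1 to compound 3 (0.04 log units; within the scatter). For compound 3 the estimated value is 3000 nM, with an expected range of 1000 nM to 9000 nM.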

Compound 3, concentration for 50% growth inhibition: 2410 nM
The estimate for compound 3 lay 1.2-fold (0.10 log units) above the measured number; the measured number falls inside the stated range.
By their numbers in this assay, from the lowest: compounds 2, 3 and 1 (each within the scatter of the next).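

Placing (4-(hydroxycarbamoyl)butyl)carbonyl in place of 4-(hydroxycarbamoyl)butyl on an amine nitrogen in a ring gives the only step that can be read in this assay, and it is a 1.1-fold lower number from compound 1 to compound 3 (0.05 log units; within the scatter). Going by these compounds alone, at this position, then, the added carbonyl, the one difference between the two structures, leaves a number that this assay does not separate from that of the parent, something the earlier compounds, which differ in more than one place, could not show. No measurement shown here bears on why the carbonyl makes no visible difference.

Compound 2 differs from both of the others in more than one place, so its steps to them cannot be read, and the chain length on this amine nitrogen stays unresolved with the carbonyl present or absent. Also open, going by these compounds, is whether a longer chain carrying the carbonyl, or a carboxylic acid in place of the hydroxycarbamoyl end of the chain, would give a number beyond the scatter of compound 1.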